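Fluoro for chloro on a weak inhibitor

This account rests on a few compounds, and the source may have more. Where it says the series, first, only, none or still open, it means among the compounds named here.

Measured in a functional assay on cells (Homo sapiens) for inhibition; on this read-out lower numbers stand for stronger inhibition and higher numbers for weaker inhibition:
compound 1 `CN(O)/C=C\C(=O)c1ccc(Cl)cc1` gives > 10000 nM (a limit)
compound 2 `CN(O)/C=C\C(=O)c1ccc(OCc2ccccc2)cc1` gives > 10000 nM (a limit)
compound 3 `O=C(/C=C\N(O)Cc1ccc2ccccc2c1)c1ccc(F)cc1` gives 7700 nM

Compound 1 stands at a limit in this assay and has no exact number: it reads > 10000 nM. Compound 2 is likewise known only as a limit, > 10000 nM. Compound 3 alone has a number, 7700 nM. The small set is therefore marked by the limit of > 10000 nM in this assay, at which 2 of the 3 values shown sit.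

Compound 4 (`CN(O)/C=C\C(=O)c1ccc(F)cc1`) keeps the core of compound 1 and makes a single exchange, fluoro in place of chloro on an aromatic carbon. The group sits para to a group of 7 heavy atoms. Going by the values given here, no measured pair shows this exchange on its own, so the data give no direct size for it. The expectation therefore starts from compound 1 and its limit of > 10000 nM. The expected change is a step that the limit leaves unreadable from compound 1 to compound 4, and no shift beyond the usual scatter is foreseen in either direction. A report of compound 4 as another limit, rather than a number, is thought likely. For compound 4 the estimated value is 12000 nM. The expected range for compound 4 runs from 6000 nM to 30000 nM.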

Compound 4, half-maximal inhibitory concentration: 5500 nM
For compound 4 the middle estimate is 2.2-fold (0.34 log units) above the measured one; the whole stated range lies above it.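

In this assay compound 4 gives 5500 nM, so a compound with a single halogen on the aromatic carbon para to a group of 7 heavy atoms now has an exact number. Compound 1, the chloro compound, has only a limit. Going by these compounds alone, the exchange of chloro for fluoro at this place gives an at least 1.8-fold lower number from compound 1 to compound 4 (0.25 log units; that floor lies within the scatter), the first step at this position that can be read at all, though only as a floor. Its true size stays unknown, and the step cannot be called a change beyond the usual scatter, because compound 1 has no exact value: the limit of > 10000 nM in this assay, at which 2 of the 4 values shown sit.

The compounds shown leave open how other groups at this same place would read, such as a bare hydrogen, a methoxy, a nitrile or a trifluoromethyl, and so whether fluoro stands out among small groups there. They also leave open whether the reading of compound 4 holds when its methyl gives way to an ethyl or a longer chain.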